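Removal of the benzyl methoxy in the sulfonamide series

The source may hold more compounds than are shown below. What is called first, only, known or untested is meant among the compounds shown, and "the series" means these compounds.

Measured so far:
compound 1 `COc1ccc(CN2CN(CC(=O)O)c3ccc(Cl)cc3S2(=O)=O)cc1` gives 5.9% in a physicochemical assay, read by spectrophotometry, with a stated time of 40 min, tested at 100 uM; on this read-out higher numbers stand for more inhibition at the one concentration tested (going by the name of the read-out) and lower numbers for less inhibition.
compound 2 `COc1ccc(CN2CN(CC(=O)O)c3ccc(OC)cc3S2(=O)=O)cc1` gives 40.6% in this assay.

Going by the values given here, compound 2 holds the higher of the two numbers; the only measured step, a number 34.7 percentage points higher from compound 1 to compound 2 (beyond the scatter), is a methoxy in place of chloro on an aromatic carbon of the shared core. Compound 3 `COc1ccc2c(c1)S(=O)(=O)N(Cc1ccccc1)CN2CC(=O)O` differs from compound 2 by hydrogen in place of methoxy on an aromatic carbon. Among the compounds with values here, this change sits on the benzyl ring, not on the core, so the one measured step does not bear on it directly; it only shows that a single substituent swap can shift this assay by a large amount. Within the data shown here, with no comparable step available, the expected step of a number 10.6 percentage points lower from compound 2 to compound 3 (beyond the scatter) for compound 3 is set as a modest loss, not clearly beyond the scatter. Compound 3 is therefore estimated at 30%, within 10% to 50%.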

Compound 3, a percentage reported as inhibition, at one concentration (the size of the read-out at that concentration, not a potency): 53.1%
Beside the measured number, compound 3's estimate is 23.1 percentage points below it, outside the stated range (above it).
By their numbers in this assay, from the lowest: compound 1; then compound 2; then compound 3.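

Going from 4-methoxybenzyl to benzyl gives, in this assay, a number 12.5 percentage points higher from compound 2 to compound 3 (beyond the scatter), so the methoxy on this ring is not required for the read-out in the presence of the methoxy on the core. The benzyl ring, at the carbon para to a large group, is therefore a second place where one substituent swap moves the number, alongside the core change in a number 34.7 percentage points higher from compound 1 to compound 2 (beyond the scatter). Nothing at hand gives a reason for this step.

The compounds shown leave open whether any other group at this benzyl position, such as an amine, a carboxylic acid or chloro, would match hydrogen or fall toward methoxy. Also open, on these data alone, is whether the step from chloro to methoxy on the core keeps its size when the benzyl ring carries only hydrogen.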